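Cyano for methoxy on the aniline ring of the thiazole series

This account rests on a few compounds, and the source may have more. Where it says the series, first, only, none or still open, it means among the compounds named here.

Compound 1 `COc1cccc(Nc2ncc(C(=O)c3ccccc3F)s2)c1`: 1000 nM
Compound 2 `O=C(c1cnc(Nc2ccc(Cl)cc2)s1)c1ccccc1F`: 1670 nM

In an assay for inhibition of Neuropeptide Y receptor type 5 (Mus musculus) (on this read-out higher numbers stand for weaker inhibition and lower numbers for stronger inhibition), compound 1 gives 1000 nM, the lower of the two numbers; compound 2 gives 1670 nM, and the two values lie within the scatter of each other, so no order between them is claimed. Compound 3 `N#Cc1cccc(Nc2ncc(C(=O)c3ccccc3F)s2)c1` differs from compound 1 by cyano in place of methoxy on an aromatic carbon. For the measured compounds named here, no measured pair shows such a change, so no direction can be taken from the data. The step from compound 1 to compound 3 is expected to stay within the scatter, no change at the digits printed from compound 1 to compound 3 (within the scatter). Compound 3 is estimated at 1000 nM, between 300 nM and 3300 nM.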

Compound 3, half-maximal inhibitory concentration: 19 nM
The estimate for compound 3 lay 53-fold (1.72 log units) above the measured number; the measured number lies below the stated range.
By their numbers in this assay, from the lowest: compound 3; then compounds 1 and 2 (each within the scatter of the next).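

In this assay, cyano in place of methoxy on an aromatic carbon, meta to a large group, gives a 53-fold lower number from compound 1 to compound 3 (1.72 log units; beyond the scatter), so the outcome at this position depends strongly on which group sits there. The two groups have the same heavy-atom and hydrogen-bond acceptor counts, so these counts alone do not predict the outcome in this single pair. Nothing measured here bears on the reason for the step.

Open, on these data alone, is how an amine, a carboxylic acid or a longer chain would read at this position. Also open, as far as these compounds go, is whether cyano gives a similar step on other members.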